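A Thioether Replaces a Sulfone on a Receptor Ligand

This account rests on a few compounds, and the source may have more. Where it says the series, first, only, none or still open, it means among the compounds named here.

Of the compounds shown here, three sharing one core have been tested in an assay for binding affinity to Corticotropin releasing factor receptor (Rattus norvegicus); a lower number here means a stronger inhibitor, a higher number a weaker inhibitor. Compound 1, `CCCC(C)n1c(CC)nc2c(-c3ccc(S(C)(=O)=O)cc3C(F)(F)F)ccnc21`, gives 6.8 nM, the largest of the three numbers. Compound 3, `CCc1nc2c(-c3ccc(C(F)(F)F)cc3Cl)ccnc2n1C(CC)COC`, gives 4.7 nM, a number that lies within the scatter of compound 1. Compound 2, `CCC(CCOC)n1c(OC)nc2c(-c3ccc(OC(F)(F)F)cc3Cl)ccnc21`, gives 1.9 nM, a number lower than that of compound 1 by more than the scatter. Compound 4, `CCCC(C)n1c(CC)nc2c(-c3ccc(SC)cc3C(F)(F)F)ccnc21`, has not been measured. It differs from compound 1 in one place: methylsulfanyl in place of methylsulfonyl on an aromatic carbon. For the measured compounds named here, no measured pair shows this change, so the expectation rests on compound 1 alone. A small step toward a lower number is expected, a 1.7-fold lower number from compound 1 to compound 4 (0.23 log units; within the scatter), near the edge of the scatter. Compound 4 is therefore estimated at 4 nM in this assay, within 1 nM to 15 nM.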

Compound 4, inhibition constant: 1.4 nM
For compound 4 the middle estimate is 2.9-fold (0.46 log units) above the measured one; measured number inside the range.
By their numbers in this assay, from the lowest: compounds 4 and 2 (each within the scatter of the next); then compounds 3 and 1 (each within the scatter of the next).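

In this assay, putting methylsulfanyl in place of methylsulfonyl on this aromatic carbon gives a 4.9-fold lower number from compound 1 to compound 4 (0.69 log units; beyond the scatter) and so lies beyond the scatter. For the compounds shown here, this is the first pair in the set that differs in one place, and it shows that the two oxygens on the sulfur are not needed for strong binding in this compound. Nothing measured here explains the change.

Still open, going by these compounds, is how methylsulfinyl, the form with one oxygen on the sulfur, would compare. Also open, on these data alone, is whether a longer chain on the sulfur, such as ethylsulfanyl, or an amine at this carbon would keep the lower number.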